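Diaryl urea series: adding chloro to compound 3

This account rests on a few compounds, and the source may have more. Where it says the series, first, only, none or still open, it means among the compounds named here.

Measured so far, in a functional assay on MCF7 cells (Homo sapiens) for inhibition, read by sulforhodamine B assay, with a stated time of 48 h, tested at 10 uM; a higher number here means a weaker effect of the compound at the concentration tested, a lower number a stronger effect:
compound 1 `COc1cc2cc(Oc3ccc(NC(=O)Nc4ccc(C)cc4)cc3)c(C)nc2cc1OC` gives 94.5%
compound 2 `COc1cc2cc(Oc3ccc(NC(=O)Nc4ccc(C(F)(F)F)cc4)cc3)c(C)nc2cc1OC` gives 84.3%
compound 3 `COc1cc2cc(Oc3ccc(NC(=O)Nc4cccc(C(F)(F)F)c4)cc3)c(C)nc2cc1OC` gives 6.81%

Compound 3 has the lowest number of the three in this assay, its nearest neighbour being compound 2 by a number 77.5 percentage points lower from compound 2 to compound 3 (beyond the scatter), the furthest compound 1 by a number 87.7 percentage points lower from compound 1 to compound 3 (beyond the scatter). Both of those steps are large and both move a substituent on the same aryl ring of the urea; the smaller step of a number 10.2 percentage points lower from compound 1 to compound 2 (beyond the scatter) is modest.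

Compound 4 `COc1cc2cc(Oc3ccc(NC(=O)Nc4ccc(Cl)c(C(F)(F)F)c4)cc3)c(C)nc2cc1OC` differs from compound 3 by chloro in place of hydrogen on an aromatic carbon. Going by the values given here, no measured step adds an atom to the ring of compound 3 while keeping the 3-(trifluoromethyl)phenyl group, so the two large steps only show that this ring decides the read-out and that compound 3 already sits near the floor of the scale. The step of a number 5.2 percentage points higher from compound 3 to compound 4 (within the scatter) is therefore expected to be small, with the risk mostly toward a higher number. Compound 4 is estimated at 12%, within 3% to 45%.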

Compound 4, a percentage reported as activity, at one concentration (the size of the read-out at that concentration, not a potency): 2.59%
Beside the measured number, compound 4's estimate is 9.4 percentage points above it; the measured number lies below the stated range.
By their numbers in this assay, from the lowest: compounds 4 and 3 (each within the scatter of the next); then compound 2; then compound 1.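

In this assay the aromatic carbon ortho to a trifluoromethyl group accepts chloro without a change beyond the scatter, with a number 4.2 percentage points lower from compound 3 to compound 4 (within the scatter) as the step for this addition. The large steps of a number 81.7 percentage points lower from compound 2 to compound 4 (beyond the scatter) and a number 91.9 percentage points lower from compound 1 to compound 4 (beyond the scatter) show that a substituent at this ring carbon does not by itself go with a high number in these compounds, since compound 4 stays far from compound 1 and compound 2 while it keeps the 3-(trifluoromethyl)phenyl group. No independent evidence bears on this result.

From the compounds shown here alone, at a single concentration, compound 3 and compound 4 cannot be separated, so whether one has a stronger or weaker effect than the other at any other concentration remains open. Also open, going by these compounds, are whether a methoxy group, a nitrile or a dimethylamino group at the same carbon would keep the number this low, and whether chloro would do so in a ring without trifluoromethyl.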